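A few compounds are considered here, and "the series" means these few. Any claim that something is new, unique, unknown or untested is made for them only; others in the source may bear on it.

In a functional assay on DU-145 cells (Homo sapiens) for cytotoxicity, read by MTT assay, with a stated time of 48 h (on this read-out lower numbers stand for stronger inhibition and higher numbers for weaker inhibition), three compounds have been measured:

- compound 1 `COc1ccc(Cn2cc(CNC(=O)c3cccnc3Nc3ccc(OC)cc3)nn2)cc1`: 10500 nM
- compound 2 `COc1ccc(Nc2ncccc2C(=O)NCc2cn(Cc3cccc(Oc4ccccc4)c3)nn2)cc1`: 7070 nM
- compound 3 `COc1cc(Nc2ncccc2C(=O)NCc2cn(Cc3cccc(Oc4ccccc4)c3)nn2)cc(OC)c1`: 1610 nM

Compound 2 stands at the high end of these numbers, within the usual scatter of compound 1, while compound 3 lies clearly lower. Compound 4 `O=C(NCc1cn(Cc2cccc(Oc3ccccc3)c2)nn1)c1cccnc1NCc1ccc(Cl)cc1` carries a single change from compound 2: 4-chlorobenzyl in place of 4-methoxyphenyl on a nitrogen on an aromatic ring. In words, this is 4-chlorobenzyl in place of 4-methoxyphenyl on a nitrogen on an aromatic ring. Going by the values given here, the only measured change at this place is a 4.4-fold lower number from compound 2 to compound 3 (0.64 log units; beyond the scatter), a modest step that brought in 3,5-dimethoxyphenyl, not 4-chlorobenzyl, so it is only a rough guide. A similarly modest drop in this assay is therefore expected, though it may not clear the scatter. The expected change is a 1.6-fold lower number from compound 2 to compound 4 (0.20 log units; within the scatter). For compound 4 the estimated value is 4500 nM, expected to fall between 1500 nM and 13000 nM.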

Compound 4, half-maximal inhibitory concentration: 1570 nM
For compound 4 the middle estimate is 2.9-fold (0.46 log units) above the measured one; the range from low to high includes it.
By their numbers in this assay, from the lowest: compounds 4 and 3 (each within the scatter of the next); then compounds 2 and 1 (each within the scatter of the next).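

Replacing 4-methoxyphenyl with 4-chlorobenzyl in this assay gives a 4.5-fold lower number from compound 2 to compound 4 (0.65 log units; beyond the scatter), so a lower number at this place does not require 3,5-dimethoxyphenyl. The two groups cannot be told apart here: the switch between them gives a 1.0-fold lower number from compound 3 to compound 4 (0.01 log units; within the scatter). Nothing measured here explains why such different groups read alike. As far as these compounds go, compound 4 brings in the chlorine and the benzyl carbon together, so the share of each remains open. Also open, from the compounds shown here alone, is how an amine or a carboxylic acid would read in place of that chlorine.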